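Cyclopropyl amides on the shared core: maximal response

The compounds below may be only part of what the source reports. "The series", "measured", "known", "first", "only" and "open" are said of these compounds alone.

Compound 1 `CCCC(=O)N1CC2CC(C1)N2` carries a propyl group on the amide carbonyl. In an assay on SH-EP1 cells for agonist activity at Neuronal acetylcholine receptor; alpha4/beta2 (Homo sapiens), read by FLIPR and calcium flux (a higher number here means a larger maximal response, a lower number a smaller maximal response), compound 1 gives 110%, level with compound 2 at the digits shown and within the scatter of compound 3. Compound 2 `O=C([C@H]1C[C@H]1F)N1CC2CC(C1)N2` gives 110% in this assay, and compound 3 `O=C([C@H]1C[C@@H]1F)N1CC2CC(C1)N2` gives 100%. The two measured steps from the propyl starting point are both flat: no change at the digits printed from compound 1 to compound 2 (within the scatter) and a number 10 percentage points lower from compound 1 to compound 3 (within the scatter). Between the two fluorocyclopropyl compounds the step is a number 10 percentage points lower from compound 2 to compound 3 (within the scatter); as the fact that one of compounds 2 and 3 is drawn with a defined configuration and the other without, at the place where they differ notes, they differ only in how one stereocentre is drawn.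

Compound 4 `C[C@@H]1C[C@H]1C(=O)N1CC2CC(C1)N2` is the next variation at the same place: 2-methylcyclopropyl in place of propyl on a carbonyl carbon. The measured steps that bear on it are the two replacements of propyl by 2-fluorocyclopropyl, neither of which moved the maximal response beyond the scatter, so a flat step in this assay is expected, with a number 5 percentage points lower from compound 1 to compound 4 (within the scatter). Compound 4 is therefore estimated at 105%, within a range of 90% to 120%.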

Compound 4, largest response reached (Emax), in percent of the reference or control that the assay uses: 110%
The estimate for compound 4 lay 5 percentage points below the measured number; measured number inside the range.
By their numbers in this assay, from the lowest: compounds 3, 1, 2 and 4 (each within the scatter of the next).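

In this assay, the flat outcome at this place no longer rests on 2-fluorocyclopropyl alone: 2-methylcyclopropyl in place of propyl on the carbonyl carbon gives no change at the digits printed from compound 1 to compound 4 (within the scatter) as well. Set against the two fluorinated amides, the same group gives no change at the digits printed from compound 2 to compound 4 (within the scatter) and a number 10 percentage points higher from compound 3 to compound 4 (within the scatter), so exchanging 2-fluorocyclopropyl for 2-methylcyclopropyl does not separate these compounds in maximal response. The compounds shown offer no measured reason for this flat behaviour.

Other drawn configurations of 2-methylcyclopropyl remain open, and a single configuration of this group cannot show whether stereochemistry matters for it. Also open, going by these compounds, is whether the maximal response holds with a longer chain, an amine or a carboxylic acid on the carbonyl carbon.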